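A few compounds are considered here, and "the series" means these few. Any claim that something is new, unique, unknown or untested is made for them only; others in the source may bear on it.

Compound 2 `C=CC[C@H]1C[C@]2([C@@H](C)Cc3ccc(OC)c(C#N)c3)OCOC2=CC1=O` is examined in a functional assay on NCI-H460 cells (Homo sapiens) for antiproliferative activity, with a stated time of 72 h (on this read-out lower numbers stand for stronger inhibition and higher numbers for weaker inhibition), where compound 2 gives 340 nM. Among the three compounds measured so far it holds the highest number. Compound 1 `C=CC[C@H]1C[C@]2([C@@H](C)Cc3ccc(OC)cc3)OCOC2=CC1=O` gives 90 nM, and compound 3 `C=CC[C@H]1C[C@]2(C(C)Cc3ccc(OC)c(OC(C)=O)c3)OCOC2=CC1=O` gives 110 nM. Among the measured compounds shown here, the one single-point step that reaches compound 2 is a 3.8-fold higher number from compound 1 to compound 2 (0.58 log units; beyond the scatter), cyano in place of hydrogen on an aromatic carbon, which raised the number beyond the scatter.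

Compound 4 `C=CC[C@H]1C[C@]2([C@@H](C)Cc3ccc(OC)c(F)c3)OCOC2=CC1=O` carries the change (fluoro in place of cyano on an aromatic carbon). The step that bears on it is the cyano step, a 3.8-fold higher number from compound 1 to compound 2 (0.58 log units; beyond the scatter), which shows that the cyano-bearing compound 2 sits well above the unsubstituted compound 1. Fluoro at this position has no measured counterpart in the series, so the expectation rests on compound 1 at 90 nM and compound 2 at 340 nM alone. A downward step is expected for compound 4, estimated as a 2.3-fold lower number from compound 2 to compound 4 (0.36 log units; beyond the scatter), since the small fluoro group sits closer to hydrogen than to cyano in what it brings. Compound 4 is therefore expected to give about 150 nM, with a range from 60 nM to 400 nM.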

Compound 4, half-maximal inhibitory concentration: 90 nM
Compound 4: the middle estimate sits 1.7-fold (0.22 log units) above what was measured; the range from low to high includes it.
By their numbers in this assay, from the lowest: compounds 1, 4 and 3 (each within the scatter of the next); then compound 2.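

Fluoro in place of hydrogen on this aromatic carbon, ortho to a methoxy group, gives no change at the digits printed from compound 1 to compound 4 (within the scatter) in this assay, so among these compounds the rise seen with cyano is not shared by every group placed here. Replacing cyano with fluoro gives a 3.8-fold lower number from compound 2 to compound 4 (0.58 log units; beyond the scatter), which singles out the cyano group, rather than the mere presence of a substituent on this carbon, as the one of the two that goes with the higher number. Nothing given here accounts for the difference between the two groups.

Going by these compounds, whether an amine, a carboxylic acid or a longer chain on this carbon would stay level with hydrogen and fluoro or move the number as cyano does remains open. So does whether fluoro would stay as neutral on the other carbons of this ring.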